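Changing the aryl group on the hydrazone carbon

This account rests on a few compounds, and the source may have more. Where it says the series, first, only, none or still open, it means among the compounds named here.

compound 1 `COc1ccc(OC)c(/C=N/NC(=O)Nc2ccc(Oc3ccnc(-c4nncn4CCN(C)C)c3)c(F)c2)c1` — 2070 nM
compound 2 `CN(C)CCn1cnnc1-c1cc(Oc2ccc(NC(=O)N/N=C/c3ccc(O)c(F)c3)cc2F)ccn1` — 3310 nM
compound 3 `CN(C)CCn1cnnc1-c1cc(Oc2ccc(NC(=O)N/N=C/c3ccc(O)cc3)cc2F)ccn1` — 1920 nM

Three compounds share one core and differ only in the aryl group attached to the carbon with a double bond to nitrogen. In a functional assay on HT-29 cells (Homo sapiens) for cytotoxicity, read by MTT assay, with a stated time of 72 h (a lower number here means a stronger inhibitor, a higher number a weaker inhibitor), compound 1 gives 2070 nM. The three numbers lie close together: the step of a 1.1-fold lower number from compound 1 to compound 3 (0.03 log units; within the scatter) and the step of a 1.6-fold higher number from compound 1 to compound 2 (0.20 log units; within the scatter) are both within the scatter, so compound 1 cannot be set apart from either of its companions.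

Compound 4 `COc1ccc(/C=N/NC(=O)Nc2ccc(Oc3ccnc(-c4nncn4CCN(C)C)c3)c(F)c2)c(OC)c1OC` is not yet measured. It differs from compound 1 in one place:
2,3,4-trimethoxyphenyl in place of 2,5-dimethoxyphenyl on a carbon with a double bond to nitrogen

For the measured compounds named here, the steps that bear on this change are the two aryl swaps already seen, a 1.6-fold higher number from compound 1 to compound 2 (0.20 log units; within the scatter) and a 1.1-fold lower number from compound 1 to compound 3 (0.03 log units; within the scatter), together with a 1.7-fold lower number from compound 2 to compound 3 (0.24 log units; within the scatter); each of them stayed within the scatter, although none replaced the 2,5-dimethoxyphenyl with another methoxy-bearing ring. With so small a set, no step beyond the scatter is expected in this assay in either direction. Compound 4 is therefore estimated at 2500 nM, in a range of 1000 nM to 6500 nM, which means an expected step of a 1.2-fold higher number from compound 1 to compound 4 (0.08 log units; within the scatter).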

Compound 4, half-maximal inhibitory concentration: 3970 nM
The estimate for compound 4 lay 1.6-fold (0.20 log units) below the measured number; measured number inside the range.
By their numbers in this assay, from the lowest: compounds 3, 1, 2 and 4 (each within the scatter of the next, the first and the last beyond it).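

In this assay, for the compounds shown here, the 2,3,4-trimethoxyphenyl group gives the first step at this position that passes the scatter, though only modestly: a 2.1-fold higher number from compound 3 to compound 4 (0.32 log units; beyond the scatter), with 4-hydroxyphenyl as the group replaced. The other two steps, a 1.9-fold higher number from compound 1 to compound 4 (0.28 log units; within the scatter) and a 1.2-fold higher number from compound 2 to compound 4 (0.08 log units; within the scatter), stay within the scatter, so the new group cannot be set apart from 2,5-dimethoxyphenyl or 3-fluoro-4-hydroxyphenyl, and the swap between the two methoxy-bearing rings makes no clear difference here. Going by these compounds alone, no measurement is available to explain the one step that passes the scatter.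

That step swaps 4-hydroxyphenyl for a ring with different groups in several places at once, so the compounds shown cannot tell which of those differences matters. On these data alone, it also remains open whether a plain phenyl, a pyridine ring, or a phenyl ring carrying an amine or a carboxylic acid on the carbon with a double bond to nitrogen would move the number further in either direction.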